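The source may report more compounds than this note shows. Statements on the series, on what has been measured and on what is new or still open speak of the compounds shown alone.

Measured in an assay on isolated protein (Oryctolagus cuniculus) with Thromboxane-A synthase (Homo sapiens) as the target, tested at 1 uM; a higher number here means more inhibition at the concentration tested (going by the name of the read-out), a lower number less inhibition:

Compound 1, `CC(C)=CCn1nc(-c2cccnc2)c2ccccc2c1=O`: 94%
Compound 2, `CCOC(=O)CCCn1nc(-c2cccnc2)c2ccccc2c1=O`: 95%
Compound 3, `O=C(c1cccs1)n1nc(-c2cccnc2)c2ccccc2c1=O`: 37%

Compound 3 stands lowest of the three in this assay. Its nearest neighbour is compound 1, and the step of a number 57 percentage points lower from compound 1 to compound 3 (beyond the scatter) is large and beyond the scatter; the step of a number 58 percentage points lower from compound 2 to compound 3 (beyond the scatter) is of the same size. Compound 1 and compound 2 lie within the scatter of each other, as the step of a number 1 percentage points higher from compound 1 to compound 2 (within the scatter) shows, so the two chain-bearing compounds cannot be ordered.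

Compound 4, `O=C(O)CCCn1nc(-c2cccnc2)c2ccccc2c1=O`, has not been measured. It differs from compound 3 in one place: 3-carboxypropyl in place of (thiophen-2-yl)carbonyl on an aromatic nitrogen. The group entering is a chain rather than the (thiophen-2-yl)carbonyl that set compound 3 apart, and it is close in build to the 3-(ethoxycarbonyl)propyl of compound 2. The two steps that bear on this change are those from compound 1 and from compound 2 to compound 3, both large and both downward; going back from compound 3 to a chain reverses them. A large upward step is therefore expected, of roughly the size a number 51 percentage points higher from compound 3 to compound 4 (beyond the scatter). Compound 4 is expected to give about 88% in this assay, within a range from 70% to 98%.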

Compound 4, a percentage reported as inhibition, at one concentration (the size of the read-out at that concentration, not a potency): 73%
Compound 4: middle estimate off by 15 percentage points, on the high side, and the stated range covers the measured number.
By their numbers in this assay, from the lowest: compound 3; then compound 4; then compounds 1 and 2 (each within the scatter of the next).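

In this assay, the step of a number 36 percentage points higher from compound 3 to compound 4 (beyond the scatter) shows that a chain ending in a carboxylic acid, the 3-carboxypropyl group, still stands well clear of the (thiophen-2-yl)carbonyl on this aromatic nitrogen. The earlier chain-bearing compounds lay within the scatter of each other, which suggested that the end of the chain made little difference; yet the step of a number 22 percentage points lower from compound 2 to compound 4 (beyond the scatter), hydrogen in place of ethyl on an oxygen next to a carbonyl group, and the step of a number 21 percentage points lower from compound 1 to compound 4 (beyond the scatter) show that the chain end does count at this position, with the free acid falling between the (thiophen-2-yl)carbonyl and the other two chains. Nothing measured here explains either the fall from the ester to the acid or the gap to the (thiophen-2-yl)carbonyl.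

The compounds shown leave open whether an amide or an amine at the end of the same chain would stay with the ester or fall with the acid, and whether a shorter or longer chain carrying the carboxylic acid would change the number. They also leave open whether the low number of compound 3 goes with the carbonyl on the aromatic nitrogen or with the thiophene ring, which a thiophen-2-ylmethyl group could separate.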